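Removing the ethyl from the aniline nitrogen of compound 1

The compounds below may be only part of what the source reports. "The series", "measured", "known", "first", "only" and "open" are said of these compounds alone.

Among the compounds with values here, compound 1 `CCN(C[C@H]1COC(N)=N1)c1cccc(Cl)c1` gives 85% in a functional assay on HEK293 cells for agonist activity at trace amine-associated receptor 1 (Homo sapiens), read by cAMP accumulation, with a stated time of 30 min (a higher number here means a larger maximal response, a lower number a smaller maximal response), which puts it second highest of the three numbers known. Compound 2 `CCN(C[C@H]1COC(N)=N1)c1ccccc1` gives 87%, and the step of a number 2 percentage points higher from compound 1 to compound 2 (within the scatter) falls within the scatter. Compound 3 `NC1=NC(c2cccc(Oc3ccccc3)c2)CO1` gives 34%, a number well below compound 1; the two structures differ in more than one place, so only the two values themselves can be compared.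

Compound 4 `NC1=N[C@@H](CNc2cccc(Cl)c2)CO1` differs from compound 1 by hydrogen in place of ethyl on a nitrogen on an aromatic ring. Within the data shown here, no measured step touches that nitrogen. Among the measured compounds shown here, the single measured step, from compound 1 to compound 2, concerns the aromatic carbon and was within the scatter, so it gives no direct guidance on the size or direction to expect here. For the measured compounds named here, with only that step available, the expectation for compound 4 is a modest lowering in this assay, estimated as a number 10 percentage points lower from compound 1 to compound 4 (within the scatter), with wide uncertainty. Compound 4 is therefore estimated at 75%, within a range of 50% to 95%.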

Compound 4, largest response reached (Emax), in percent of the reference or control that the assay uses: 58%
Compound 4: the middle estimate sits 17 percentage points above what was measured, within the range that was stated.
By their numbers in this assay, from the lowest: compound 3; then compound 4; then compounds 1 and 2 (each within the scatter of the next).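

In this assay, within the data shown here, the ethyl on the nitrogen on an aromatic ring is not interchangeable with hydrogen: the change gives a number 27 percentage points lower from compound 1 to compound 4 (beyond the scatter) and is the only single change that moves the maximal response beyond the scatter. The other single change, hydrogen in place of chloro on an aromatic carbon, gives a number 2 percentage points higher from compound 1 to compound 2 (within the scatter) and so leaves the response of the series unmoved within the scatter. The response therefore depends on the substituent at this nitrogen more than on the chloro, though only for this pair of steps, and nothing at hand bears on the reason for the loss.

Going by these compounds, whether a methyl, or a chain longer than ethyl such as propyl, on this nitrogen would keep the response of compound 1 remains open. On these data alone, it is also open whether the loss on removing the ethyl would be the same size on the core of compound 2, which carries no chloro.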